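Permeability notes on a quinoline ether series

A few compounds are considered here, and "the series" means these few. Any claim that something is new, unique, unknown or untested is made for them only; others in the source may bear on it.

Three compounds have been measured in an ADME assay for permeability, using PAMPA, with a stated time of 30 min, at pH 7.4; on this read-out lower numbers stand for lower permeability and higher numbers for higher permeability:
compound 1 `COc1ccc(F)cc1CNCCCNc1ccnc2cc(Oc3ccc(F)cc3)ccc12` gives 317 10^-6 cm/s;
compound 2 `COc1ccc(F)cc1CNCCCNc1ccnc2cc(Oc3cccc(N(C)C)c3)ccc12` gives 317 10^-6 cm/s;
compound 3 `COc1cccc(CNCCCNc2ccnc3cc(Oc4cccc(N(C)C)c4)ccc23)c1O` gives 317 10^-6 cm/s.

Compound 1 differs from compound 2 by 4-fluorophenyl in place of 3-(dimethylamino)phenyl on an oxygen on an aromatic ring, and the step of no change at the digits printed from compound 2 to compound 1 (within the scatter). Compound 3 differs from compound 2 in the other part of the molecule, by 2-hydroxy-3-methoxyphenyl in place of 5-fluoro-2-methoxyphenyl on a saturated chain carbon bound to an amine nitrogen, and the step of no change at the digits printed from compound 2 to compound 3 (within the scatter). The three values therefore sit together in this assay, and no ordering can be read among them.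

Compound 4 `COc1cccc(CNCCCNc2ccnc3cc(Oc4ccc(F)cc4)ccc23)c1O` is not yet measured. It differs from compound 3 by 4-fluorophenyl in place of 3-(dimethylamino)phenyl on an oxygen on an aromatic ring, the same change that carries compound 2 to compound 1, made here on the core of compound 3, whose difference from the core of compound 2 is 2-hydroxy-3-methoxyphenyl in place of 5-fluoro-2-methoxyphenyl on a saturated chain carbon bound to an amine nitrogen. Because no change at the digits printed from compound 2 to compound 1 (within the scatter) showed no change, the expected step is no change at the digits printed from compound 3 to compound 4 (within the scatter). Compound 4 is estimated at 317 10^-6 cm/s, expected between 200 10^-6 cm/s and 400 10^-6 cm/s.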

Compound 4, apparent permeability: 317 10^-6 cm/s
Compound 4: the middle estimate sits on the measured number at the digits printed, and the stated range covers the measured number.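

In this assay, 4-fluorophenyl in place of 3-(dimethylamino)phenyl gives no change at the digits printed from compound 3 to compound 4 (within the scatter), and the change reads alike on both cores: the same change on two cores in this assay, no change at the digits printed (within the scatter) from compound 2 to compound 1 and no change at the digits printed (within the scatter) from compound 3 to compound 4, 1.0-fold (0.00 log units) apart, within the scatter of two such steps

2-Hydroxy-3-methoxyphenyl in place of 5-fluoro-2-methoxyphenyl gives no change at the digits printed from compound 1 to compound 4 (within the scatter), again alike on both cores: the same change on two cores in this assay, no change at the digits printed (within the scatter) from compound 2 to compound 3 and no change at the digits printed (within the scatter) from compound 1 to compound 4, 1.0-fold (0.00 log units) apart, within the scatter of two such steps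

Both changes thus carry across these cores only as steps of no visible size, which does not show how a step of real size would carry, nor how either change would read on any other core.

Still open, on these data alone, is whether a carboxylic acid on the aromatic ring, or a longer chain in the shared core, would give a value that differs in this assay. The four compounds shown leave that question untouched.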